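Series notes: aryl change on compound 3 in this assay

The source may hold more compounds than are shown below. What is called first, only, known or untested is meant among the compounds shown, and "the series" means these compounds.

Compound 2 `Cc1nc(-c2cccc(F)c2)sc1COc1ccc2c(c1)OCC2CC(=O)O` and compound 3 `Cc1nc(-c2ccc(F)cc2)sc1COc1ccc2c(c1)OCC2CC(=O)O` share one core and differ only in the position of a single fluoro. In a functional assay on CHO cells for agonist activity at Free fatty acid receptor 1 (Homo sapiens), read by FLIPR and calcium flux (on this read-out higher numbers stand for an effect only at larger amounts of compound and lower numbers for an effect already at smaller amounts), compound 2 gives 64.8 nM and compound 3 gives 48.7 nM; the step of a 1.3-fold lower number from compound 2 to compound 3 (0.12 log units; within the scatter) moves only within the scatter, so the two stand as equals. Compound 3 thus holds the lowest of the two numbers available, with compound 2 as its nearest neighbour. Compound 1 `Cc1nc(-c2ccc(Cl)s2)sc1COc1ccc2c(c1)OCC2CC(=O)O` belongs to the same core, but in this assay compound 1 gives "not determined" (no result reported), so no number for it is available here.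

Compound 4 `COc1ccc(-c2nc(C)c(COc3ccc4c(c3)OCC4CC(=O)O)s2)cc1` arises from compound 3 by methoxy in place of fluoro on an aromatic carbon. For the measured compounds named here, no measured step covers this exchange: the only step available shows that moving a fluoro between two places on the same ring changes little, which says nothing direct about replacing it with methoxy. No reason to expect a large movement is found in the two numbers, so a step near zero, within the scatter, is the working expectation, written as a 1.0-fold higher number from compound 3 to compound 4 (0.01 log units; within the scatter). Compound 4 is therefore expected to give about 50 nM in this assay, with a range from 18 nM to 160 nM to cover the unmeasured exchange.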

Compound 4, half-maximal effective concentration: 123 nM
Compound 4: middle estimate off by 2.5-fold (0.39 log units), on the low side, within the range that was stated.
By their numbers in this assay, from the lowest: compounds 3, 2 and 4 (each within the scatter of the next, the first and the last beyond it).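

In this assay, for the compounds shown here, the exchange of fluoro for methoxy on this aromatic carbon, para to a large group, is the first change to pass beyond the scatter, with a 2.5-fold higher number from compound 3 to compound 4 (0.40 log units; beyond the scatter), a modest step, whereas the shift of the fluoro within the ring had moved nothing that could be read. The result is limited by the second comparison, a 1.9-fold higher number from compound 2 to compound 4 (0.28 log units; within the scatter), which stays within the scatter, so the effect of the methoxy can be read only against compound 3 and not against compound 2, even though compound 2 and compound 3 stand as equals. Nothing among the data shown offers an explanation for the step from fluoro to methoxy.

With only fluoro and methoxy on this ring, one step cannot show whether the number follows the size of the group, its oxygen or something else, and an ethoxy, an amine or a carboxylic acid at the same carbon would each test this further. From the compounds shown here alone, it also remains open whether methoxy at the place that carries the fluoro in compound 2 would give a step like the one seen here.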